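Trading phenyl for oxan-4-yl on a saturated ring carbon

The source may hold more compounds than are shown below. What is called first, only, known or untested is meant among the compounds shown, and "the series" means these compounds.

For the measured compounds named here, in a physicochemical assay for lipophilicity, at pH 7.4 (on this read-out lower numbers stand for lower lipophilicity and higher numbers for higher lipophilicity), compound 1 `CNC(=O)c1cc(C(=O)N[C@H]2[C@@H]3COC[C@@H]32)cc2c1OC[C@H]2c1ccccc1` reads 3.3 and stands highest of the two numbers measured so far, while compound 2 `CNC(=O)c1cc(C(N)=O)cc2c1OC[C@H]2c1ccccc1` reads 2.7 on the same scale. Compound 3 `CNC(=O)c1cc(C(=O)N[C@H]2[C@@H]3COC[C@@H]32)cc2c1OC[C@H]2C1CCOCC1` has not been measured yet. It differs from compound 1 in one place: oxan-4-yl in place of phenyl on a saturated ring carbon. Going by the values given here, the only measured step is a number 0.60 log units lower from compound 1 to compound 2 (beyond the scatter) and it lies at an amide-type nitrogen, elsewhere on the molecule, so it gives a sense of scale and no direct precedent for this swap. A six-membered aromatic ring of carbon only gives way to a non-aromatic ring with a hetero atom, so a fall is expected. The estimated step is a number 1.00 log units lower from compound 1 to compound 3 (beyond the scatter) in this assay and it is expected to exceed that yardstick somewhat. For compound 3 the estimated value is 2.3 with an expected range of 1.8 to 2.8 on this scale.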

Compound 3, distribution coefficient: 2.1
Compound 3: the middle estimate sits 0.20 log units above what was measured, within the range that was stated.
By their numbers in this assay, from the lowest: compound 3; then compound 2; then compound 1.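

In this assay, the saturated ring carbon proves to be a sensitive place: oxan-4-yl in place of phenyl gives a number 1.20 log units lower from compound 1 to compound 3 (beyond the scatter) and counts as a large step, even though both groups hold 6 heavy atoms. Removing the whole group on the amide-type nitrogen gave a smaller, modest change (a number 0.60 log units lower from compound 1 to compound 2 (beyond the scatter)), so swapping one ring for another of equal atom count here moves the reading further than that deletion did. Nothing available accounts for the size of this fall.

From the compounds shown here alone, the swap changes two things at once, removing the aromatic ring and bringing in a ring oxygen, so the share of each stays open. A cyclohexyl ring, non-aromatic and all carbon, or a pyridine ring, aromatic with a nitrogen, at this same carbon would begin to separate them.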